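A Shorter Diol Side Chain on the Aromatic Nitrogen

A few compounds are considered here, and "the series" means these few. Any claim that something is new, unique, unknown or untested is made for them only; others in the source may bear on it.

Measured so far:
- compound 1, `O=C1c2c[n+]([O-])c3ccccc3c2C(=O)c2c1c1ccccc1n2Cc1cn([C@H]2C[C@H](O)[C@@H](CO)O2)nn1`: 120 nM
- compound 2, `O=C1c2c[n+]([O-])c3ccccc3c2C(=O)c2c1c1ccccc1n2CCCN1CCC(O)CC1`: 190 nM

In a functional assay on HCT-116 cells (Homo sapiens) for cytotoxicity, read by MTT assay, with a stated time of 72 h (on this read-out higher numbers stand for weaker inhibition and lower numbers for stronger inhibition), compound 1 gives the lowest of the two numbers, and compound 2 sits close to it, within the usual scatter, so no order between them can be claimed. Compound 3, `O=C1c2c[n+]([O-])c3ccccc3c2C(=O)c2c1c1ccccc1n2Cc1cn(C[C@H](O)CO)nn1`, keeps the shared core of compound 1 and differs only at the side chain: 2,3-dihydroxypropyl in place of 4-hydroxy-5-(hydroxymethyl)oxolan-2-yl on an aromatic nitrogen. Among the compounds with values here, with no step between measured compounds to lean on, the change is expected to give at most a small step in this assay, perhaps a slight weakening, not clearly beyond the scatter. Compound 3 is therefore estimated at 180 nM (range 70 nM to 450 nM), which means an expected step of a 1.5-fold higher number from compound 1 to compound 3 (0.18 log units; within the scatter).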

Compound 3, half-maximal inhibitory concentration: 400 nM
Compound 3: middle estimate off by 2.2-fold (0.35 log units), on the low side; low and high end bracket the measured number.
By their numbers in this assay, from the lowest: compounds 1 and 2 (each within the scatter of the next); then compound 3.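

In this assay, the side chain on the aromatic nitrogen proves sensitive to change: 2,3-dihydroxypropyl in place of 4-hydroxy-5-(hydroxymethyl)oxolan-2-yl gives a 3.3-fold higher number from compound 1 to compound 3 (0.52 log units; beyond the scatter). The 1-(2,3-dihydroxypropyl)-1H-1,2,3-triazol-4-yl group in place of 2-(4-hydroxypiperidin-1-yl)ethyl likewise gives a weaker result, with a 2.1-fold higher number from compound 2 to compound 3 (0.32 log units; beyond the scatter). No measurement here explains either step.

The compounds shown do not separate the effect of losing the ring from that of losing atoms or stereocentres. As far as these compounds go, how a primary amine or a carboxylic acid at the end of this side chain would behave also remains open.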